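The source may report more compounds than this note shows. Statements on the series, on what has been measured and on what is new or still open speak of the compounds shown alone.

Of the compounds shown here, two built on a shared core have been measured in a functional assay on BJAB cells (Homo sapiens) for antiproliferative activity, with a stated time of 4 days; a lower number here means that less compound is needed, a higher number that more compound is needed for the effect. Compound 1 `COc1ccc(C)cc1-c1c(C)nn(-c2nc(-c3ccc(Cl)c(Cl)c3)c(SC(C)C)s2)c1C(=O)O` gives 9500 nM in this assay, the higher of the two numbers. Compound 2 `Cc1c(-c2cc(Cl)cc(Cl)c2)c(C(=O)O)nn1-c1nc(-c2cc(Cl)cc(Cl)c2)c(SC(C)C)s1` differs from compound 1 at more than one place. In this assay compound 2 gives 2000 nM, a number lower than that of compound 1 by more than the usual scatter of repeated measurements. Compound 3 `COc1ccccc1-c1c(C)nn(-c2nc(-c3ccc(Cl)c(Cl)c3)c(SC(C)C)s2)c1C(=O)O` has not yet been measured; it differs from compound 1 in a single place: hydrogen in place of methyl on an aromatic carbon. Within the data shown here, nothing among the measured compounds shows what the loss of a methyl at this place does in this assay, so the expectation rests on compound 1 alone. For compound 3, the step of a 1.3-fold higher number from compound 1 to compound 3 (0.10 log units; within the scatter) is expected to be small, likely within the usual scatter, with no clear direction. Compound 3 is therefore estimated at 12000 nM, within a range from 4000 nM to 35000 nM.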

Compound 3, half-maximal effective concentration: 14700 nM
Estimate against measurement, compound 3: 1.2-fold (0.09 log units) below; the range from low to high includes it.
By their numbers in this assay, from the lowest: compound 2; then compounds 1 and 3 (each within the scatter of the next).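

In this assay, among these compounds, the change from 2-methoxy-5-methylphenyl to 2-methoxyphenyl gives a 1.5-fold higher number from compound 1 to compound 3 (0.19 log units; within the scatter) and is the first direct reading of this position. At this carbon, para to a methoxy group, the methyl can therefore be replaced by hydrogen without a change that this assay can tell apart from ordinary repeat variation. Nothing available explains this small step.

On these data alone, only methyl and hydrogen are seen at this place, so what an amine, a hydroxyl group or a propyl chain would do here remains unknown. As far as these compounds go, it also remains open whether the step would stay this small without the methoxy group that compound 1 and compound 3 share.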